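This account rests on a few compounds, and the source may have more. Where it says the series, first, only, none or still open, it means among the compounds named here.

Compound 1 `Cc1cc(S(N)(=O)=O)ccc1NC(=O)COc1ccc(Cl)cc1NC(=O)c1cccc([N+](=O)[O-])c1`: 58800 nM
Compound 2 `COc1ccc(C(=O)Nc2cc(Cl)ccc2OCC(=O)Nc2ccc(S(N)(=O)=O)cc2C)cc1`: 69500 nM
Compound 3 `Cc1cc(C)cc(C(=O)Nc2cc(Cl)ccc2OCC(=O)Nc2ccc(S(N)(=O)=O)cc2C)c1`: 36500 nM

These values come from a functional assay on C8166 cells (Homo sapiens) for cytotoxicity, read by MTT assay; on this read-out higher numbers stand for lower toxicity in this test and lower numbers for higher toxicity in this test. On them, compound 3 cannot be told apart from the other two. The steps reaching it are a 1.6-fold lower number from compound 1 to compound 3 (0.21 log units; within the scatter) and a 1.9-fold lower number from compound 2 to compound 3 (0.28 log units; within the scatter). Compound 4 `Cc1cc(S(N)(=O)=O)ccc1NC(=O)COc1ccc(Cl)cc1NC(=O)/C=C/c1ccccc1` is still unmeasured. It carries 2-phenylethenyl in place of 3,5-dimethylphenyl on a carbonyl carbon. The steps above exchange the group at this same place, and so does the third, a 1.2-fold higher number from compound 1 to compound 2 (0.07 log units; within the scatter). None of them tests a double bond outside aromatic rings. Even so, no step beyond the scatter is expected in this assay. The expected change is a 1.2-fold higher number from compound 3 to compound 4 (0.09 log units; within the scatter). For compound 4 the estimated value is 45000 nM, with an expected range from 18000 nM to 110000 nM.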

Compound 4, half-maximal cytotoxic concentration: 163000 nM
The estimate for compound 4 lay 3.6-fold (0.56 log units) below the measured number, and the stated range ends below it.
By their numbers in this assay, from the lowest: compounds 3, 1 and 2 (each within the scatter of the next); then compound 4.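

At this place on a carbonyl carbon, the three substituted phenyl groups stayed within the scatter of one another in this assay, but 2-phenylethenyl moves the number beyond it, toward lower toxicity in this test (a 4.5-fold higher number from compound 3 to compound 4 (0.65 log units; beyond the scatter); a 2.3-fold higher number from compound 2 to compound 4 (0.37 log units; beyond the scatter); a 2.8-fold higher number from compound 1 to compound 4 (0.44 log units; beyond the scatter)). Compound 3 and compound 4 carry groups of equal heavy-atom count, so that count does not separate them; the double bond outside aromatic rings is what the entering group adds. No measurement shown explains the step. Going by these compounds, whether the double bond itself matters stays open; a comparison with 2-phenylethyl, the same group with a saturated chain, would test that.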